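This account rests on a few compounds, and the source may have more. Where it says the series, first, only, none or still open, it means among the compounds named here.

Compound 1 `CCCS(=O)(=O)Nc1cccc2c1CCC2c1ncc[nH]1` gives 1340 nM in a functional assay on CHO cells for agonist activity at Alpha-1A adrenergic receptor (Homo sapiens), read by FLIPR and calcium flux; a lower number here means that less compound is needed, a higher number that more compound is needed for the effect. Compound 2 `c1cc(-c2ccn[nH]2)c2c(c1)C(c1ncc[nH]1)CC2` gives 52 nM. Compound 3 `Cc1c(OCC2=NCCN2)ccc(Cl)c1NS(C)(=O)=O` gives 25 nM.

Compound 1 stands highest of the three numbers. The nearest neighbour is reached by a 26-fold lower number from compound 1 to compound 2 (1.41 log units; beyond the scatter), and compound 3 lies further still from compound 1. Compound 4 `COc1cccc2c1CCC2c1ncc[nH]1` differs from compound 1 by methoxy in place of (propylsulfonyl)amino on an aromatic carbon. Among the measured compounds shown here, the only step that bears on this change is a 26-fold lower number from compound 1 to compound 2 (1.41 log units; beyond the scatter), a large one, though it introduced a different group at the same place. A methoxy is a smaller replacement, so a smaller shift is expected, still toward a lower number; the expected step is a 2.7-fold lower number from compound 1 to compound 4 (0.43 log units; beyond the scatter). Compound 4 is therefore estimated at 500 nM, with a likely range from 150 nM to 2000 nM.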

Compound 4, half-maximal effective concentration: 32 nM
Compound 4: the middle estimate sits 16-fold (1.19 log units) above what was measured; the measured number lies below the stated range.
By their numbers in this assay, from the lowest: compounds 3, 4 and 2 (each within the scatter of the next, the first and the last beyond it); then compound 1.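

In this assay, a group of only 2 heavy atoms on this aromatic carbon is enough for a large step (a 42-fold lower number from compound 1 to compound 4 (1.62 log units; beyond the scatter)), so the earlier large step did not require a ring to enter here. Methoxy and 1H-pyrazol-5-yl are not separated in this assay (a 1.6-fold lower number from compound 2 to compound 4 (0.21 log units; within the scatter)). Nothing shown explains why (propylsulfonyl)amino carries the higher number.

On these data alone, whether a hydroxyl, an amine or an ethoxy on this carbon would fall with compound 2 and compound 4 remains open. So does whether (methylsulfonyl)amino, with its shorter chain, would stay with compound 1.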